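The source may hold more compounds than are shown below. What is called first, only, known or untested is meant among the compounds shown, and "the series" means these compounds.

Compound 3 `COc1cc(C(=O)N/N=C/c2c(Cl)cccc2Cl)cc(OC)c1OC` stands lowest of the three compounds in a functional assay on BGC-823 cells (Homo sapiens) for antiproliferative activity, read by MTT assay, tested at 1 uM (a lower number here means a weaker effect, a higher number a stronger effect of the compound at the concentration tested), where compound 3 gives 0.9%. Compound 1 `COc1cc(C(=O)N/N=C/c2ccc(F)c(F)c2)cc(OC)c1OC` gives 33.1%, and compound 2 `COc1cc(C(=O)N/N=C/c2ccccc2C(F)(F)F)cc(OC)c1OC` gives 22.1%. The change toward compound 4 `COc1cc(C(=O)N/N=C/c2ccccc2F)cc(OC)c1OC` is 2-fluorophenyl in place of 2,6-dichlorophenyl on a carbon with a double bond to nitrogen. For the measured compounds named here, one measured step bears on it: the step of a number 32.2 percentage points lower from compound 1 to compound 3 (beyond the scatter), which went from a 3,4-difluorophenyl to the 2,6-dichlorophenyl that now leaves. Compound 4 keeps a single fluorine on the ring, closer in kind to compound 1 and compound 2 than to compound 3. Since compound 1 gave 33.1% with a fluorinated ring, an upward step is expected for compound 4, a number 23.1 percentage points higher from compound 3 to compound 4 (beyond the scatter). Compound 4 is therefore estimated at 24%, within a range of 8% to 40%.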

Compound 4, a percentage reported as inhibition, at one concentration (the size of the read-out at that concentration, not a potency): 51.6%
Compound 4: middle estimate off by 27.6 percentage points, on the low side; the whole stated range lies below it.
By their numbers in this assay, from the lowest: compound 3; then compound 2; then compound 1; then compound 4.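

In this assay the 2-fluorophenyl on the carbon with a double bond to nitrogen gives the highest number of the four compounds, with a number 50.7 percentage points higher from compound 3 to compound 4 (beyond the scatter) and a number 29.5 percentage points higher from compound 2 to compound 4 (beyond the scatter) as well as a number 18.5 percentage points higher from compound 1 to compound 4 (beyond the scatter) on the same ring place. The 3,4-difluorophenyl is thus no longer the best ring shown, and fluorinated rings differ clearly among themselves, so fluorine alone does not set the number here.

From the compounds shown here alone, how an amine or a carboxylic acid on this ring would read remains open. Nothing given here accounts for these steps.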